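The source may report more compounds than this note shows. Statements on the series, on what has been measured and on what is new or still open speak of the compounds shown alone.

Compound 1 `COCCCCCCCCCCCCCCC/C=C1\CC(CO)(COC(=O)C(C)(C)C)OC1=O`: in a functional assay on NCI-H322 cells (Homo sapiens) for antiproliferative activity (a higher number here means a weaker inhibitor of growth, a lower number a stronger inhibitor of growth), compound 1 gives > 10 ug/mL, which is a limit of the assay and not a number.
Compound 2 `COC(=O)CCCCCCCCCCCCCC/C=C1\CC(CO)(COC(=O)C(C)(C)C)OC1=O`: compound 2 gives > 10 ug/mL, again only a limit.
Compound 3 `CC(C)(C)C(=O)OCC1(CO)C/C(=C\CCCCCCCCCCCO)C(=O)O1`: compound 3 gives > 10 ug/mL, also only a limit.

Compound 1 thus stands where every value here stands, and nothing more can be read of it: the limit of > 10 ug/mL in this assay, at which 3 of the 3 values shown sit. Compound 4 `CC(=O)OCCCCCCCCCCCCCCC/C=C1\CC(CO)(COC(=O)C(C)(C)C)OC1=O` differs from compound 1 in one place, (acetyl in place of methyl on an oxygen on a saturated carbon). The three measured steps, a step that the two limits leave unreadable from compound 1 to compound 2, a step that the two limits leave unreadable from compound 1 to compound 3 and a step that the two limits leave unreadable from compound 2 to compound 3, each run between two limits and give no size at all. With nothing readable to build on, no step beyond the scatter is expected in this assay from the methoxy-to-acetoxy change. Compound 4 is therefore expected to stay at the limit, estimated at 15 ug/mL (from 5 ug/mL to 50 ug/mL). This means an expected step that the limit leaves unreadable from compound 1 to compound 4.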

Compound 4, concentration for 50% growth inhibition: > 10 ug/mL
Compound 4: only a limit was reported; the forecaster's own chance of this, stated with the estimate: 80%; the middle value does not contradict the limit.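

Within the data shown here, compound 4 sits at a limit, as do compound 1, compound 2 and compound 3, so no step among them can be read: the limit of > 10 ug/mL in this assay, at which 4 of the 4 values shown sit. From the compounds shown here alone, whether changing the chain end alters growth inhibition in this assay stays open.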